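This account rests on a few compounds, and the source may have more. Where it says the series, first, only, none or still open, it means among the compounds named here.

Compound 3 `CCCCCCCC/C=C\CCCCCCC(=O)c1ncco1` gives 17 nM in an assay on isolated protein for inhibition of Fatty-acid amide hydrolase 1 (Homo sapiens) (on this read-out higher numbers stand for weaker inhibition and lower numbers for stronger inhibition), the second highest of the three numbers measured. Its nearest neighbour is compound 2 `CCCCCCCC/C=C\CCCCCCC(=O)c1nc2cnccc2o1`, which gives 7.2 nM; the step of a 2.4-fold higher number from compound 2 to compound 3 (0.37 log units; beyond the scatter) is modest. Furthest away is compound 1 `CCCCCCCC/C=C\CCCCCCC(=O)c1cccnn1`, which gives 130 nM; the step of a 7.6-fold lower number from compound 1 to compound 3 (0.88 log units; beyond the scatter) is modest, while an 18-fold lower number from compound 1 to compound 2 (1.26 log units; beyond the scatter) is large. Compound 4 `CCCCCCCC/C=C\CCCCCCC(=O)c1nnn(C)n1` differs from compound 3 in one place: 2-methyl-2H-tetrazol-5-yl in place of 1,3-oxazol-2-yl on a carbonyl carbon. Among the measured compounds shown here, both measured steps at this carbonyl carbon moved the number beyond the scatter, so another exchange of the ring here is expected to move it as well, although no measured step shows a ring of this kind. Compound 4 is therefore expected to give 30 nM, within 8 nM to 120 nM. The expected step of a 1.8-fold higher number from compound 3 to compound 4 (0.25 log units; within the scatter) would be modest, toward a higher number.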

Compound 4, inhibition constant: 65 nM
Compound 4: middle estimate off by 2.2-fold (0.34 log units), on the low side, within the range that was stated.
By their numbers in this assay, from the lowest: compound 2; then compound 3; then compounds 4 and 1 (each within the scatter of the next).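

Exchanging the ring at this carbonyl carbon for 2-methyl-2H-tetrazol-5-yl loses ground against both rings with the lower numbers (a 3.8-fold higher number from compound 3 to compound 4 (0.58 log units; beyond the scatter); a 9.0-fold higher number from compound 2 to compound 4 (0.96 log units; beyond the scatter)). Since 1,3-oxazol-2-yl is also a five-membered aromatic ring, that ring size alone does not secure a low number here. Against pyridazin-3-yl, the exchange gives no difference beyond the scatter (a 2.0-fold lower number from compound 1 to compound 4 (0.30 log units; within the scatter)).

Nothing at hand accounts for these differences. Open, from the compounds shown here alone, is how a 1,3-thiazol-2-yl group would fare on this carbonyl carbon, and whether this order of rings would persist with a shorter chain.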